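The source may hold more compounds than are shown below. What is called first, only, known or untested is meant among the compounds shown, and "the series" means these compounds.

Three compounds have been measured in a functional assay on HT-29 cells (Homo sapiens) for cytotoxicity, read by MTT assay, with a stated time of 72 h; a lower number here means a stronger inhibitor, a higher number a weaker inhibitor:

compound 1 `Cc1c(/N=C/c2ccc(N(C)C)cc2)c(=O)n(-c2ccccc2)n1C`, 331000000 nM
compound 2 `Cc1c(/N=C/c2cccc([N+](=O)[O-])c2)c(=O)n(-c2ccccc2)n1C`, 741000000 nM
compound 3 `COc1cccc(/C=N/c2c(C)n(C)n(-c3ccccc3)c2=O)c1O`, 240000000 nM

Compound 2 gives the highest of the three numbers in this assay, and its gaps to compound 1 and to compound 3 both lie beyond the scatter, so it is the weakest inhibitor of this small set. Compound 4 `Cc1c(/N=C/c2cccc(Cl)c2)c(=O)n(-c2ccccc2)n1C` differs from compound 2 by chloro in place of nitro on an aromatic carbon. For the measured compounds named here, no measured pair shows this change, so no step can be drawn from the data. Because compound 1 sits at 331000000 nM and compound 3 at 240000000 nM, a slight drift toward a lower number is the most that is anticipated in this assay, and a step within the scatter is equally plausible. The expected step is a 1.6-fold lower number from compound 2 to compound 4 (0.22 log units; within the scatter). Compound 4 is estimated at 450000000 nM, with a range from 150000000 nM to 1200000000 nM.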

Compound 4, half-maximal inhibitory concentration: 269000000 nM
Compound 4: the middle estimate sits 1.7-fold (0.22 log units) above what was measured; measured number inside the range.
By their numbers in this assay, from the lowest: compounds 3, 4 and 1 (each within the scatter of the next); then compound 2.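

For the compounds shown here, with chloro in place of nitro on this aromatic carbon, this assay gives a 2.8-fold lower number from compound 2 to compound 4 (0.44 log units; beyond the scatter), the first single-place comparison in the set. Going by these compounds alone, it shows that the group at this position can move the number beyond the scatter, which the earlier compounds, with no pair differing in one place, could not show. Nothing available explains why this change has this effect. From the compounds shown here alone, whether an amine, a carboxylic acid or a methoxy group on the same aromatic carbon would give a lower or a higher number remains open.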